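This account rests on a few compounds, and the source may have more. Where it says the series, first, only, none or still open, it means among the compounds named here.

Measured in a functional assay on K562 cells (Homo sapiens) for antiproliferative activity, read by CellTiter-Glo, with a stated time of 72 h; a higher number here means that more compound is needed for the effect, a lower number that less compound is needed:
- compound 1 `CCCCCCCNc1ncnc2c1ncn2[C@@H]1O[C@H](COS(N)(=O)=O)[C@@H](O)[C@H]1O`: 132 nM
- compound 2 `CC(C)(C)CCNc1ncnc2c1ncn2[C@@H]1O[C@H](COS(N)(=O)=O)[C@@H](O)[C@H]1O`: 929 nM
- compound 3 `NS(=O)(=O)OC[C@H]1O[C@@H](n2cnc3c(NCC4CCCO4)ncnc32)[C@H](O)[C@@H]1O`: > 1000 nM (a limit of the assay, not a number)

Compound 3 stands at the limit of > 1000 nM in this assay, at which 1 of the 3 values shown sits. Compound 4 `NS(=O)(=O)OC[C@H]1O[C@@H](n2cnc3c(N4CCC5CCCCC5C4)ncnc32)[C@H](O)[C@@H]1O` differs from it at one place, on an aromatic carbon of the shared core: a group of 10 heavy atoms (9 carbon, 1 nitrogen; one six-membered non-aromatic ring of carbon only, one six-membered non-aromatic ring with 1 hetero atom) in place of a group of 7 heavy atoms (5 carbon, 1 nitrogen, 1 oxygen; one five-membered non-aromatic ring with 1 hetero atom), on an aromatic carbon. The ((oxolan-2-yl)methyl)amino group leaves, and a group with one six-membered non-aromatic ring of carbon only and one six-membered non-aromatic ring with 1 hetero atom enters.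

Three measured steps at this same place bear on the change. Going from a hexyl to an oxolan-2-yl end gave an at least 7.5-fold higher number from compound 1 to compound 3 (0.87 log units; beyond the scatter), and the same exchange against neopentyl gave an at least 1.0-fold higher number from compound 2 to compound 3 (0.03 log units; that floor lies within the scatter). The shape of an all-carbon group also counts, as a 7.0-fold higher number from compound 1 to compound 2 (0.85 log units; beyond the scatter) shows. Within the data shown here, no measured compound lacks a hydrogen on the nitrogen attached to the aromatic carbon, so the data give no direct guide for that feature of compound 4.

A return toward the value of compound 2 at 929 nM seems more likely than one toward the value of compound 1 at 132 nM. The expected step is small and toward a lower number, an at least 1.2-fold lower number from compound 3 to compound 4 (0.09 log units; that floor lies within the scatter), and it may stay within the scatter. Compound 4 is estimated at 800 nM, with an expected range from 200 nM to 3000 nM.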

Compound 4, half-maximal effective concentration: > 1000 nM
Compound 4: no number, only a limit (the forecaster's own chance of this, stated with the estimate: 40%); at least 1.2-fold (0.09 log units) between middle value and limit.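

In this assay compound 4 gives > 1000 nM and that is a limit of the assay, not a number. Among these compounds, the entering group is the first here with no hydrogen-bond donor on this aromatic carbon, and it brings no return toward compound 1: the data show an at least 7.5-fold higher number from compound 1 to compound 4 (0.87 log units; beyond the scatter) and, against the smaller open-chain group, an at least 1.0-fold higher number from compound 2 to compound 4 (0.03 log units; that floor lies within the scatter) while the step from compound 3 cannot be read, as both ends of it are limits. With the fused pair of six-membered rings on this carbon, compound 4 joins compound 3 at the ceiling of the assay: the limit of > 1000 nM in this assay, at which 2 of the 4 values shown sit.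

Going by these compounds, how far past that limit compound 3 and compound 4 lie stays unknown, so the ((oxolan-2-yl)methyl)amino group and the fused ring group cannot be ranked against each other. Also open, on these data alone, is whether the loss of the hydrogen on the nitrogen matters by itself or only together with the ring size, a question that a methyl on that nitrogen of the open chain of compound 1, or a plain piperidine at the same aromatic carbon, would help to separate.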